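The compounds below may be only part of what the source reports. "The series", "measured", "known", "first", "only" and "open" are said of these compounds alone.

Measured compounds in a functional assay on 786-0 cells (Homo sapiens) for inhibition, read by sulforhodamine B assay, with a stated time of 48 h; on this read-out higher numbers stand for weaker inhibition of growth and lower numbers for stronger inhibition of growth:
- compound 1 `COc1ccc(/C=C/C2CC(=O)C=CO2)cc1`, with compound 1 at 192 uM
- compound 2 `COc1ccc(C2CC(=O)C=CO2)cc1`, with compound 2 at 197 uM

Both measured compounds sit at the weak end of the concentration scale. Compound 2 has the higher of the two numbers, but its nearest neighbour, compound 1, lies within the scatter of repeated measurements, so no order between compound 1 and compound 2 can be read from these two values; the only firm statement is that both are weak growth inhibitors on this read-out. Going by the values given here, no step between measured compounds that differ in a single place is available, so the series gives no anchor for the size of any single change.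

Compound 3 `COc1ccc(C2CC(=O)C(Br)=CO2)cc1` is the next compound to be measured. Relative to compound 2 the change is bromo in place of hydrogen on a double-bonded ring carbon. Among the compounds with values here, with no comparable step among the measured compounds, the expected step from compound 2 to compound 3 in this assay is taken as a 1.3-fold lower number from compound 2 to compound 3 (0.12 log units; within the scatter), that is, a small shift, not firmly beyond the scatter, with the range left wide on both sides. On that basis compound 3 is estimated at 150 uM, within a range from 50 uM to 400 uM.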

Compound 3, concentration for growth inhibition (reported as GI): 33.4 uM
The estimate for compound 3 lay 4.5-fold (0.65 log units) above the measured number; the whole stated range lies above it.
By their numbers in this assay, from the lowest: compound 3; then compounds 1 and 2 (each within the scatter of the next).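

In this assay, going by these compounds alone, bromo in place of hydrogen on a double-bonded ring carbon gives a 5.9-fold lower number from compound 2 to compound 3 (0.77 log units; beyond the scatter), the first step that lies beyond the scatter. Compound 1 at 192 uM and compound 2 at 197 uM lie within the scatter of each other and gave no sign of where the number could be moved, whereas this position, two ring bonds from the ring oxygen, responds to the entry of a single bromine atom. The entering group brings no ring, no hydrogen-bond donor or acceptor and no net charge, and nothing measured alongside these numbers bears on the reason for the step.

From the compounds shown here alone, whether the step is particular to bromo or would also follow from another group on the same ring carbon stays open, and chloro, methyl or a nitrile there would test this. Also open, going by these compounds, is whether bromo at this position would give a step of similar size on the core of compound 1, and whether an amine or a carboxylic acid would be tolerated there.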